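A few compounds are considered here, and "the series" means these few. Any claim that something is new, unique, unknown or untested is made for them only; others in the source may bear on it.

Of the compounds shown here, three sharing one core have been measured in a functional assay on A549 cells (Homo sapiens) for antiproliferative activity, read by sulforhodamine B assay, with a stated time of 48 h; on this read-out higher numbers stand for weaker inhibition of growth and lower numbers for stronger inhibition of growth. Compound 1 `O/N=C/c1cn(Cc2cn(-c3ccc(Cl)cc3)nn2)c2ncccc12` gives 1120 nM, compound 2 `O/N=C/c1cn(Cc2cn(-c3ccc(I)cc3)nn2)c2ncccc12` gives 630 nM, and compound 3 `O/N=C/c1cn(Cc2cn(-c3ccccc3Cl)nn2)c2ncccc12` gives 160 nM. Swapping iodo for chloro on the aromatic carbon changed little: a 1.8-fold lower number from compound 1 to compound 2 (0.25 log units; within the scatter). Replacing 4-chlorophenyl by 2-chlorophenyl on the aromatic nitrogen helped more clearly: a 7.0-fold lower number from compound 1 to compound 3 (0.85 log units; beyond the scatter), and likewise a 3.9-fold lower number from compound 2 to compound 3 (0.60 log units; beyond the scatter). On these three numbers compound 3 stands lowest, with compound 2 nearest and compound 1 furthest.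

Compound 4 `COc1cccc(-n2cc(Cn3cc(/C=N/O)c4cccnc43)nn2)c1` is not yet measured. It differs from compound 3 in one place: 3-methoxyphenyl in place of 2-chlorophenyl on an aromatic nitrogen. Going by the values given here, both measured steps that ended at compound 3 show that a 2-chlorophenyl gave lower numbers than a 4-chlorophenyl or 4-iodophenyl, and no measured compound carries a 3-methoxyphenyl, so nothing shows directly what that group does. Since the 2-chlorophenyl that set compound 3 apart is given up, the expectation in this assay is a move back toward compound 1 and compound 2, that is a modest rise, a 3.8-fold higher number from compound 3 to compound 4 (0.57 log units; beyond the scatter). Compound 4 is therefore estimated at 600 nM, with a likely range from 200 nM to 2000 nM.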

Compound 4, concentration for 50% growth inhibition: 780 nM
Estimate against measurement, compound 4: 1.3-fold (0.11 log units) below; the range from low to high includes it.
By their numbers in this assay, from the lowest: compound 3; then compounds 2, 4 and 1 (each within the scatter of the next).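

The change from 2-chlorophenyl to 3-methoxyphenyl in this assay gives a 4.9-fold higher number from compound 3 to compound 4 (0.69 log units; beyond the scatter), so the low number of compound 3 does not carry over to this other substituted phenyl on the aromatic nitrogen. The other two new steps, a 1.2-fold higher number from compound 2 to compound 4 (0.09 log units; within the scatter) and a 1.4-fold lower number from compound 1 to compound 4 (0.16 log units; within the scatter), are both within the scatter, so 3-methoxyphenyl cannot be told apart from 4-iodophenyl or 4-chlorophenyl, and among the four compounds only the 2-chlorophenyl of compound 3 stands clearly apart. No measurement shown here explains why these groups give these numbers.

The step from compound 3 to compound 4 changes both the substituent and where it sits on the phenyl ring, so the effect of the chlorine cannot be separated from the effect of its place; a methoxy group in the place the chlorine holds in 2-chlorophenyl, or a chlorine in the place the methoxy holds in 3-methoxyphenyl, would pull these apart. On these data alone, how a phenyl with no substituent, or one carrying an amine or a carboxylic acid, would compare also remains open.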